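Ethoxycarbonylmethyl in Place of 4-Methoxybenzyl: an Expectation

This account rests on a few compounds, and the source may have more. Where it says the series, first, only, none or still open, it means among the compounds named here.

Measured so far in a functional assay with Mus musculus as the target; on this read-out lower numbers stand for an effect already at smaller amounts and higher numbers for an effect only at larger amounts of compound:
- compound 1, `C=CCn1c(=S)n([C@@H]2O[C@H](CO)[C@H]3OC(C)(C)O[C@H]32)c2nc(N)nc(O)c21`, gives 45 uM
- compound 2, `COc1ccc(Cn2c(=O)n(C3OC(CO)[C@@H](O)[C@H]3O)c3nc(N)nc(O)c32)cc1`, gives 2 uM
- compound 3, `C=CCn1c(=S)n(COCCO)c2nc(N)nc(O)c21`, gives 13 uM

Among these three, compound 2 stands lowest, meaning it produces its effect at the smallest amount. Compound 3 sits closer to it, and compound 1 is furthest away; both gaps lie beyond the usual scatter of repeated measurements, so compound 2 is the most potent of the three on this read-out. Among the compounds with values here, none of the three differs from another in only one place, so no single-change step can be drawn between them.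

Compound 4, `CCOC(=O)Cn1c(=O)n(C2OC(CO)[C@@H](O)[C@H]2O)c2nc(N)nc(O)c21`, has not yet been measured. It is derived from compound 2 by one change: ethoxycarbonyl in place of 4-methoxyphenyl on a saturated chain carbon bound to an aromatic nitrogen. A ring-bearing arm is thus exchanged for a shorter chain carrying a carbonyl.

Nothing in the measured set isolates this exchange. Compound 3, which carries a short chain rather than a ring at the corresponding place, gives a higher number than compound 2, but it also differs elsewhere, so that comparison is only a loose hint. The expectation is a moderate rise in the number, that is a weaker effect, with a step of a 3.0-fold higher number from compound 2 to compound 4 (0.48 log units; beyond the scatter). Compound 4 is therefore estimated at 6 uM, within a range from 1.5 uM to 25 uM.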

Compound 4, concentration for half-maximal effect: 630 uM
Compound 4: middle estimate off by 110-fold (2.02 log units), on the low side, and the stated range ends below it.
By their numbers in this assay, from the lowest: compound 2; then compound 3; then compound 1; then compound 4.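

In this assay, within the data shown here, putting ethoxycarbonyl in place of 4-methoxyphenyl on a saturated chain carbon bound to an aromatic nitrogen gives a 320-fold higher number from compound 2 to compound 4 (2.50 log units; beyond the scatter) and this is the first reading of a single change at this place, with the rest of the structure held the same. The earlier compounds shown here differ from one another in more than one place, so they could not show that the read-out depends this strongly on the group carried here. The change removes the aromatic ring, shortens the group and brings in a carbonyl all at once, and nothing measured here separates these parts or explains the result.

The compounds shown leave open whether the ring itself matters or whether the ester is what costs so much, a question that a plain phenyl or a simple propyl chain at this place could help to settle. They also leave open how a carboxylic acid or an amide would behave in place of the ethoxycarbonyl, and whether a longer chain carrying the same ester would read any differently.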